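A few compounds are considered here, and "the series" means these few. Any claim that something is new, unique, unknown or untested is made for them only; others in the source may bear on it.

Working notes on the series. The shared core is seen bare in compound 1 `O=C1C=CS(=O)(=O)c2ccccc21`, which in a functional assay on the whole organism for inhibition, with Mus musculus as the target, at a dose of 10 mg/kg (a lower number here means less inhibition, a higher number more inhibition at the dose given (going by the name of the read-out)), gives 5.5%. Compound 2 `CC(C)OCC1=CS(=O)(=O)c2ccccc2C1=O` carries an isopropoxymethyl on a double-bonded ring carbon and in this assay gives 99.2%; compound 3 `CCC(=O)OCC1=CS(=O)(=O)c2ccccc2C1=O` carries a (propanoyloxy)methyl there and in this assay gives 99.5%. Compound 3 thus holds the highest of the three numbers, but compound 2 lies within the scatter of it. The two steps from the bare core are large: a number 93.7 percentage points higher from compound 1 to compound 2 (beyond the scatter) and a number 94 percentage points higher from compound 1 to compound 3 (beyond the scatter). The step between the two substituted compounds is not: a number 0.3 percentage points higher from compound 2 to compound 3 (within the scatter).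

Compound 4 `O=C1C(CO)=CS(=O)(=O)c2ccccc21` is the next member: hydrogen in place of propanoyl on an oxygen on a saturated carbon. Within the data shown here, no measured step covers a hydroxymethyl directly. What bears on it is that the (propanoyloxy)methyl and the isopropoxymethyl arm give the same number, so the group on the oxygen has so far been exchangeable without consequence, and the gain in this assay tracks the presence of the oxymethyl arm itself. As far as these compounds go, compound 4 keeps that arm, so inhibition is expected to stay high, with a step of a number 11.5 percentage points lower from compound 3 to compound 4 (beyond the scatter) expected; some loss is allowed since a hydrogen on the oxygen is untested. Compound 4 is estimated at 88%, in the range 55% to 100%.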

Compound 4, a percentage reported as inhibition, in the whole organism at one dose (the size of the read-out at that dose, not a potency): 99.3%
For compound 4 the middle estimate is 11.3 percentage points below the measured one; measured number inside the range.
By their numbers in this assay, from the lowest: compound 1; then compounds 2, 4 and 3 (each within the scatter of the next).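

With a hydrogen on the oxygen, the arm reads the same within the scatter as with propanoyl (a number 0.2 percentage points lower from compound 3 to compound 4 (within the scatter)) and as with isopropyl (a number 0.1 percentage points higher from compound 2 to compound 4 (within the scatter)). The hydroxymethyl on the double-bonded ring carbon is thus enough by itself for a large step from the bare core (a number 93.8 percentage points higher from compound 1 to compound 4 (beyond the scatter)), and compounds 2, 3 and 4 show no need for a larger group on the oxygen in this assay. Nothing at hand explains why the three arms read alike.

Whether the oxygen of the arm is needed stays open, as a plain methyl or an aminomethyl on that ring carbon is not among the compounds shown. A single dose also leaves open whether compounds 2, 3 and 4 would separate at lower doses.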